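Urea aryl swap in a cytotoxicity screen

The source may report more compounds than this note shows. Statements on the series, on what has been measured and on what is new or still open speak of the compounds shown alone.

Measured compounds:
compound 1 `O=C(Nc1cccc(-n2cc(-c3ccncc3)c(-c3ccc(Cl)c(O)c3)n2)c1)Nc1ccc(Cl)c(Cl)c1` gives > 32500 nM
compound 2 `COc1cc(-c2nn(-c3cccc(NC(=O)Nc4ccc(Cl)c(C(F)(F)F)c4)c3)cc2-c2ccncc2)ccc1Cl` gives > 32500 nM
compound 3 `COc1cc(-c2nn(-c3cccc(NC(=O)c4ccccc4)c3)cc2-c2ccncc2)ccc1Cl` gives > 100000 nM

In a functional assay on RXF 393 cells (Homo sapiens) for inhibition, read by sulforhodamine B assay, with a stated time of 48 h (a lower number here means that less compound is tolerated, a higher number that more compound is tolerated), every value recorded so far is a limit of the assay, not a number. Compound 1 stands at the limit of > 32500 nM in this assay, at which 2 of the 3 values shown sit, together with compound 2. Compound 3 stands at the limit of > 100000 nM in this assay, at which 1 of the 3 values shown sits. For the measured compounds named here, the only step between measured compounds that differ in one place is a step that the two limits leave unreadable from compound 2 to compound 3, and since both ends are limits its size cannot be read. Compound 1 therefore has no measured neighbour that tells how much a change on its urea end matters.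

Compound 4 `O=C(Nc1cccc(-n2cc(-c3ccncc3)c(-c3ccc(Cl)c(O)c3)n2)c1)Nc1cccc(C(F)(F)F)c1` differs from compound 1 by 3-(trifluoromethyl)phenyl in place of 3,4-dichlorophenyl on an amide-type nitrogen. Going by the values given here, none of the measured steps involves this change, so nothing measured bears on it directly. What the data do show is that three compounds of this shared core, with differing groups on the carbonyl carbon or on the amide-type nitrogen, all sit at limits in this assay. Compound 4 is therefore expected to behave alike, with a step that the limit leaves unreadable from compound 1 to compound 4 that is expected to be none beyond the scatter. The estimate for compound 4 is 50000 nM, in a range from 20000 nM to 150000 nM, most probably reported again as a limit.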

Compound 4, concentration lethal to 50% of the cells: > 32500 nM
Compound 4: a limit, no number; the forecaster's own chance of this, stated with the estimate: 80%; the middle value is on the limit's open side.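

In this assay compound 4 gives > 32500 nM, a limit of the assay and not a number. Compound 1 also stands at a limit, so no step can be read between compound 1 and compound 4. The compounds shown leave open whether any group on the urea end changes the read-out at all, since none has yielded a number.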